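Working notes: from compound 2 to compound 3

The compounds below may be only part of what the source reports. "The series", "measured", "known", "first", "only" and "open" are said of these compounds alone.

Compound 1 `O=C(CCCCC1CCSS1)NCc1cn(CCCCCOc2ccc3ccc(=O)oc3c2)nn1` gives 64.5% in a functional assay on PC-12 cells (Rattus norvegicus) for cytotoxicity, read by MTT assay, with stated times of 3 h and 2 h, tested at 5 uM; a lower number here means a weaker effect, a higher number a stronger effect of the compound at the concentration tested. Compound 2 `O=C(CCCCC1CCSS1)NCc1cn(CCCCCOc2ccc3cc(-c4ccccc4)c(=O)oc3c2)nn1` gives 28% in this assay, the lowest of the two numbers shown; the single measured step is a number 36.5 percentage points lower from compound 1 to compound 2 (beyond the scatter). Compound 3 `COc1ccc(-c2cc3ccc(OCCCCCn4cc(CNC(=O)CCCCC5CCSS5)nn4)cc3oc2=O)cc1OC` carries the change (3,4-dimethoxyphenyl in place of phenyl on an aromatic carbon). For the measured compounds named here, no measured step tests this change directly; the step from compound 1 to compound 2 concerns a different pair of groups on an aromatic carbon and shows only that the read-out responds to what sits there. No step beyond the scatter is therefore expected, and compound 3 is estimated at 28% with a range of 14% to 45%, an expected step of no change at the digits printed from compound 2 to compound 3 (within the scatter).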

Compound 3, a percentage reported as activity, at one concentration (the size of the read-out at that concentration, not a potency): 46.9%
Compound 3: middle estimate off by 18.9 percentage points, on the low side; measured number outside the range, above it.
By their numbers in this assay, from the lowest: compound 2; then compound 3; then compound 1.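

In this assay, the phenyl at this position is sensitive to substitution: 3,4-dimethoxyphenyl in place of phenyl gives a number 18.9 percentage points higher from compound 2 to compound 3 (beyond the scatter) in this pair. Against hydrogen, the same group still gives a number 17.6 percentage points lower from compound 1 to compound 3 (beyond the scatter) at this position, so it regains only part of the loss seen with phenyl. Nothing available explains this difference between the two aryl groups. On these data alone, what remains open is whether a single methoxy on the phenyl accounts for the change, and how an amine or a carboxylic acid there would read.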